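Replacing a Pyridyl Arm with a Methoxyethoxy Chain

The compounds below may be only part of what the source reports. "The series", "measured", "known", "first", "only" and "open" are said of these compounds alone.

Compound 3 `C=CC(=O)Nc1cccc(Nc2ncnc(Nc3ccc(-c4ccc(OC)nc4)cc3)n2)c1` carries a 6-methoxypyridin-3-yl group on the outer aromatic ring, and its result in a functional assay on Raji cells (Homo sapiens) for antiproliferative activity, read by CCK-8 assay, with a stated time of 24 h (on this read-out higher numbers stand for weaker inhibition and lower numbers for stronger inhibition), is recorded as "not determined" (no result reported). The same is true of compound 2 `C=CC(=O)Nc1cccc(Nc2ncnc(Nc3ccc(-c4ccc(Cl)nc4)cc3)n2)c1`, whose value in this assay is "not determined" (no result reported). So compound 3 stands without a number among the compounds shown, and only compound 1 `C=CC(=O)Nc1cccc(Nc2nc(N)nc(Nc3ccc(OCCOC)cc3)n2)c1` offers a reading: in this assay compound 1 gives 18300 nM, a weak result.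

Compound 4 `C=CC(=O)Nc1cccc(Nc2ncnc(Nc3ccc(OCCOC)cc3)n2)c1` differs from compound 3 by a single exchange: 2-methoxyethoxy in place of 6-methoxypyridin-3-yl on an aromatic carbon. The 2-methoxyethoxy group that enters is the same group found in compound 1, whose core differs from that of compound 4 by one further substituent.

Within the data shown here, with no measured step on which to rest a direction, compound 4 is expected to lie in the weak range that compound 1 occupies in this assay, with a value estimated at 15000 nM, most likely between 4000 nM and 50000 nM.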

Compound 4, half-maximal inhibitory concentration: 105000 nM
For compound 4 the middle estimate is 7.0-fold (0.85 log units) below the measured one, outside the stated range (above it).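

In this assay, among these compounds, the one readable comparison lies in the shared core and not on the outer aromatic ring. With 2-methoxyethoxy held constant, hydrogen in place of amino gives a 5.7-fold higher number from compound 1 to compound 4 (0.76 log units; beyond the scatter) and so moves the number well beyond the usual scatter, which shows that this one change on the core is enough to weaken an already weak result. The exchange of 6-methoxypyridin-3-yl for 2-methoxyethoxy cannot be read: compound 3 has no number to set against compound 4. Nothing at hand gives a reason for the step.

On these data alone, it remains open whether amino on the core would have the same effect with 6-methoxypyridin-3-yl on the outer ring. Also open, as far as these compounds go, is how a longer chain, an amine or a carboxylic acid would fare in place of 2-methoxyethoxy.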